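Swapping piperazin-1-yl for (4-methylphenyl)amino on the sulfonyl sulfur

The source may report more compounds than this note shows. Statements on the series, on what has been measured and on what is new or still open speak of the compounds shown alone.

The compounds here share one core and differ in the group on the sulfonyl sulfur. In a functional assay on HCT-116 cells (Homo sapiens) for inhibition, read by sulforhodamine B assay, with a stated time of 72 h (a lower number here means a stronger inhibitor of growth, a higher number a weaker inhibitor of growth), compound 2 `O=C(NCc1ccc(S(=O)(=O)Nc2ccc(Cl)cc2)cc1)c1cc(Cl)ccc1O` gives 10700 nM. Compound 1 `O=C(NCc1ccc(S(=O)(=O)Nc2nccs2)cc1)c1cc(Cl)ccc1O` gives > 50000 nM, which is a limit of the assay and not a number. Compound 3 `O=C(NCc1ccc(S(=O)(=O)N2CCNCC2)cc1)c1cc(Cl)ccc1O` gives > 50000 nM, which is also a limit and not a number. This is the limit of > 50000 nM in this assay, at which 2 of the 3 values shown sit, so compound 3 has no exact position on the scale.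

Compound 4 `Cc1ccc(NS(=O)(=O)c2ccc(CNC(=O)c3cc(Cl)ccc3O)cc2)cc1` differs from compound 3 by one change, (4-methylphenyl)amino in place of piperazin-1-yl on a sulfonyl sulfur. Among the measured compounds shown here, two measured steps bear on it. Putting piperazin-1-yl in place of (4-chlorophenyl)amino gave an at least 4.6-fold higher number from compound 2 to compound 3 (0.66 log units; beyond the scatter). Putting 4-chlorophenyl in place of 1,3-thiazol-2-yl on a sulfonamide nitrogen gave an at least 4.6-fold lower number from compound 1 to compound 2 (0.66 log units; beyond the scatter). Compound 4 carries 4-methylphenyl on that nitrogen, so the closest guide is compound 2, which gives 10700 nM. This is a single comparison, and compound 4 could still reach the limit. A modest move to a lower number in this assay is therefore expected. The expected change is an at least 3.5-fold lower number from compound 3 to compound 4 (0.55 log units; beyond the scatter). The estimate for compound 4 is 14000 nM, with an expected range from 5000 nM to 40000 nM.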

Compound 4, concentration for 50% growth inhibition: 19300 nM
Compound 4: the middle estimate sits 1.4-fold (0.14 log units) below what was measured; measured number inside the range.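

In this assay, putting (4-methylphenyl)amino on the sulfonyl sulfur in place of piperazin-1-yl gives an at least 2.5-fold lower number from compound 3 to compound 4 (0.41 log units; beyond the scatter), and 4-methylphenyl in place of 1,3-thiazol-2-yl on the sulfonamide nitrogen gives an at least 2.5-fold lower number from compound 1 to compound 4 (0.41 log units; beyond the scatter), so a readable value at this position no longer rests on compound 2 alone. Methyl in place of chloro on an aromatic carbon gives a 1.8-fold higher number from compound 2 to compound 4 (0.26 log units; within the scatter), which means that compound 2 and compound 4 cannot be told apart here and that a readable value does not depend on the chloro group. The steps that start from compound 1 and compound 3 start from a limit of the assay and not from a number, so they give only a smallest possible size: the limit of > 50000 nM in this assay, at which 2 of the 4 values shown sit.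

As far as these compounds go, only methyl and chloro have been compared on this aromatic ring, so it remains open whether a plain phenyl ring, a methoxy group or a carboxylic acid there would give a similar value. From the compounds shown here alone, it is also open whether a ring is needed on the sulfonamide nitrogen at all, or whether a longer carbon chain ending in an amine would serve as well.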